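Swapping acetyl for trifluoromethyl in a weak inhibitor

The compounds below may be only part of what the source reports. "The series", "measured", "known", "first", "only" and "open" are said of these compounds alone.

Among the compounds with values here, in a functional assay for inhibition, with Rattus norvegicus as the target (a lower number here means a stronger inhibitor, a higher number a weaker inhibitor), compound 2 (`CC(=O)c1ccc(/N=c2\c(O)c(O)\c2=N/C(C)C(C)(C)C)cc1`) gives 21200 nM as the only true number so far. Compound 1 (`CC(/N=c1\c(O)c(O)\c1=N/c1ccc(OC(F)(F)F)cc1)C(C)(C)C`) gives > 30000 nM as a limit of the assay. Compound 3 (`CC(/N=c1\c(O)c(O)\c1=N/c1ccc(C(F)(F)F)cc1)C(C)(C)C`) differs from compound 2 at one place: trifluoromethyl in place of acetyl on an aromatic carbon in short, trifluoromethyl in place of acetyl on an aromatic carbon. Within the data shown here, the only measured step changing a group there is an at least 1.4-fold lower number from compound 1 to compound 2 (0.15 log units; that floor lies within the scatter) and it offers no clear trend. That step rests on the limit of > 30000 nM in this assay, at which 1 of the 2 values shown sits, and gives only a floor. No step beyond the scatter is expected in this assay and no direction can be argued. The estimated step is a 1.1-fold lower number from compound 2 to compound 3 (0.03 log units; within the scatter) in size. Compound 3 is expected near 20000 nM with an estimated range from 6000 nM to 45000 nM overall.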

Compound 3, half-maximal inhibitory concentration: > 30000 nM
Compound 3: only a limit was reported; the forecaster's own chance of this, stated with the estimate: 40%; at least 1.5-fold (0.17 log units) between middle value and limit.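

In this assay, compound 3 gives > 30000 nM, which is a limit and not a true number. The change from acetyl to trifluoromethyl reads as an at least 1.4-fold higher number from compound 2 to compound 3 (0.15 log units; that floor lies within the scatter), so at this position acetyl is still the only group with a true number, and no real difference between the two groups is shown. The step from compound 1 to compound 3 cannot be read, and the results crowd at one edge of the assay: the limit of > 30000 nM in this assay, at which 2 of the 3 values shown sit.

Going by these compounds, whether any group here can give a clearly lower number than compound 2 stays open. How an amine or a carboxylic acid in place of acetyl would read is also unknown.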